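Swapping 4-methoxyphenyl for 2-methylphenyl in compound 4

The source may hold more compounds than are shown below. What is called first, only, known or untested is meant among the compounds shown, and "the series" means these compounds.

Measured so far in an ADME assay on THP-1 cells (Homo sapiens) for cytotoxicity, read by MTT assay, with a stated time of 72 h (on this read-out higher numbers stand for weaker inhibition and lower numbers for stronger inhibition), are three compounds

- compound 1 (`COc1cccc(/C=C/C(=O)c2c(O)c3ccccc3[nH]c2=O)c1`) gives 38500 nM as a number
- compound 2 (`CCn1c(=O)c(C(=O)/C=C/c2ccccc2C)c(O)c2ccccc21`) gives > 50000 nM as a limit of the assay
- compound 3 (`COc1ccc(/C=C/C(=O)c2c(O)c3ccccc3[nH]c2=O)cc1`) gives > 50000 nM as a limit of the assay

Compound 3 stands at the limit of > 50000 nM in this assay, at which 2 of the 3 values shown sit, and so has no exact number of its own.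

Compound 4 (`Cc1ccccc1/C=C/C(=O)c1c(O)c2ccccc2[nH]c1=O`) has not been measured yet. It carries 2-methylphenyl in place of 4-methoxyphenyl on a double-bonded chain carbon bound to a double-bonded chain carbon.

For the measured compounds named here, one measured step bears on this same place. As far as these compounds go, putting 4-methoxyphenyl in place of 3-methoxyphenyl gave an at least 1.2-fold higher number from compound 1 to compound 3 (0.11 log units; that floor lies within the scatter) and this is only a floor, so the true size of that step is unknown. Compound 2 already carries 2-methylphenyl on a different core, and its reading of > 50000 nM is also a limit.

With only this to go on, no step beyond the scatter is expected. The estimated move is a number no higher from compound 3 to compound 4 (the limit leaves the size open) in this assay and it is expected to be small in either direction. For compound 4 the expected value is 50000 nM with an estimated range from 25000 nM to 100000 nM and a reading at the limit would be no surprise.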

Compound 4, half-maximal inhibitory concentration: > 50000 nM
Compound 4 ended at the assay's limit (the forecaster's own chance of this, stated with the estimate: 55%); the middle value sits exactly at the limit.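

In this assay, putting 2-methylphenyl in place of 4-methoxyphenyl gives compound 4, whose reading is again a limit of the assay and not a number, so the steps to compound 4 from compound 2 and compound 3 cannot be read. For the compounds shown here, the only step that can be read is an at least 1.2-fold higher number from compound 1 to compound 4 (0.11 log units; that floor lies within the scatter), and as a floor it gives no true size for the change from 3-methoxyphenyl to 2-methylphenyl. What compound 4 adds is that a group with no oxygen, placed on the core of compound 1 with hydrogen on the aromatic nitrogen, also gives no exact number, so the readings now gather at one end of the scale: the limit of > 50000 nM in this assay, at which 3 of the 4 values shown sit.

As far as these compounds go, how far compound 2, compound 3 and compound 4 truly lie from one another remains unknown, as does any real ranking of the 2-methylphenyl and 4-methoxyphenyl groups at this place. Also open, from the compounds shown here alone, is whether an amine or a carboxylic acid on a double-bonded chain carbon's phenyl group would give a number that can be read.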